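Aryl in place of sulfonamide on the five-membered ring

The source may hold more compounds than are shown below. What is called first, only, known or untested is meant among the compounds shown, and "the series" means these compounds.

Compound 1 `O=C1O/C(=C\Cn2cc(-c3cc(F)cc(F)c3)nn2)C(OCc2ccccc2)=C1OCc1ccccc1` was run in a functional assay on CFPAC-1 cells (Homo sapiens) for antiproliferative activity, read by MTT assay, with a stated time of 72 h (a lower number here means a stronger inhibitor, a higher number a weaker inhibitor), and was recorded as "not active" (no number reported), with no number reported. Within the data shown here, compound 2 `O=C1O[C@H]([C@@H](O)Cn2cc(CNS(=O)(=O)c3ccc(F)cc3)nn2)C(OCc2ccccc2)=C1OCc1ccccc1` gives 34700 nM in this assay; it is the only number in hand, so compound 2 stands alone and no ordering against another measured compound can be drawn. Compound 3 `COc1ccc(-c2cn(C[C@H](O)[C@H]3OC(=O)C(OCc4ccccc4)=C3OCc3ccccc3)nn2)cc1` is not yet measured in this assay. It differs from compound 2 in one place: 4-methoxyphenyl in place of (((4-fluorophenyl)sulfonyl)amino)methyl on an aromatic carbon. Among the measured compounds shown here, no step between two measured compounds is available, so the size of this change is not known from data. Compound 1 also carries a six-membered aromatic ring of carbon only on the five-membered aromatic ring with 3 nitrogen and was not active, but it differs from compound 3 elsewhere as well, so it settles nothing on its own. The expected step is a 1.4-fold higher number from compound 2 to compound 3 (0.16 log units; within the scatter), toward a weaker inhibitor or none beyond the scatter. Compound 3 is estimated at 50000 nM, with a range from 15000 nM to 150000 nM, and a fair chance that only a limit is returned.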

Compound 3, half-maximal inhibitory concentration: 26000 nM
Compound 3: the middle estimate sits 1.9-fold (0.28 log units) above what was measured, and the stated range covers the measured number.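

In this assay, among these compounds, 4-methoxyphenyl in place of (((4-fluorophenyl)sulfonyl)amino)methyl gives a 1.3-fold lower number from compound 2 to compound 3 (0.13 log units; within the scatter), the first step that can be read at this aromatic carbon. The two groups therefore cannot be told apart in this assay, although the exchange goes from 12 heavy atoms to 8, from 1 hydrogen-bond donor to 0 and from 2 hydrogen-bond acceptors to 1. Both groups carry one six-membered aromatic ring of carbon only, and this ring attached directly to the aromatic carbon, with no sulfonamide-bearing link, still returns a number. No measured property of these groups accompanies this result.

From the compounds shown here alone, whether an amine or a carboxylic acid at this aromatic carbon, or a longer chain carrying the six-membered aromatic ring, would move the number beyond the scatter remains open. Also open, going by these compounds, is the contribution of the hydroxyl-bearing chain shared by compound 2 and compound 3, since compound 1 differs from compound 3 in more than one place and its result cannot be assigned to any single part of the structure.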